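Acylating the Free Amine of Compound 2

A few compounds are considered here, and "the series" means these few. Any claim that something is new, unique, unknown or untested is made for them only; others in the source may bear on it.

Measured compounds:
Compound 1, `CCCCCCCCCCCCCCN(NC(=O)COC)C(=O)CCCCCCCCC`: in a functional assay on K562 cells (Homo sapiens) for antiproliferative activity, read by resazurin assay, with a stated time of 72 h (on this read-out higher numbers stand for weaker inhibition of growth and lower numbers for stronger inhibition of growth), compound 1 gives > 110000 nM, which is a limit of the assay and not a number.
Compound 2, `CCCCCCCCCCCCCCN(N)C(=O)OC(C)(C)C`: compound 2 gives 58700 nM in this assay.

Among the measured compounds shown here, compound 2 thus holds the only numerical value shown; the other reading is a limit, (the limit of > 110000 nM in this assay, at which 1 of the 2 values shown sits). Compound 3, `CCCCCCCCCCCCCCN(NC(=O)COC)C(=O)OC(C)(C)C`, is not yet measured in this assay. It differs from compound 2 in one place: (methoxymethyl)carbonyl in place of hydrogen on an amine nitrogen, which cut one bond further out reads as amino to ((methoxymethyl)carbonyl)amino. For the measured compounds named here, no step between measured compounds is available to calibrate this change. Compound 1 carries the same ((methoxymethyl)carbonyl)amino group and reaches only the limit (the limit of > 110000 nM in this assay, at which 1 of the 2 values shown sits), so one expects the step from compound 2 to compound 3 to weaken inhibition beyond the scatter, with the risk that only a limit is returned. The estimate for compound 3 in this assay is 100000 nM, ranging from 40000 nM to 250000 nM, and the estimated step is a 1.7-fold higher number from compound 2 to compound 3 (0.23 log units; within the scatter).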

Compound 3, concentration for 50% growth inhibition: 40900 nM
For compound 3 the middle estimate is 2.4-fold (0.39 log units) above the measured one; measured number inside the range.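

In this assay, placing (methoxymethyl)carbonyl on the amine nitrogen of compound 2 changes nothing that can be read, with a 1.4-fold lower number from compound 2 to compound 3 (0.16 log units; within the scatter), so the ((methoxymethyl)carbonyl)amino group on its own does not carry a loss of growth inhibition. What separates the two acylated compounds is tert-butoxy in place of nonyl on a carbonyl carbon, with an at least 2.6-fold lower number from compound 1 to compound 3 (0.42 log units; beyond the scatter). The reading of compound 1 is a limit of the assay and not a number: the limit of > 110000 nM in this assay, at which 1 of the 3 values shown sits.

The compounds shown leave open whether an acyl group ending in an amine or a carboxylic acid would behave like (methoxymethyl)carbonyl on this nitrogen. They also leave open how a shorter chain on the amide-type nitrogen, or a carbonyl group other than these two, would read.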